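Swapping a chloro for a methoxy on a furanone scaffold

The source may report more compounds than this note shows. Statements on the series, on what has been measured and on what is new or still open speak of the compounds shown alone.

Compound 1 `O=C1OC(c2ccc(Cl)cc2)=C/C1=C\c1ccc(Cl)cc1` has the higher of the two measured numbers in a functional assay on the whole organism (strain Wistar) for inhibition, with Rattus norvegicus as the target, with stated times of 30 min and 2 h, at a dose of 20 mg/kg by the oral route (a higher number here means more inhibition at the dose given (going by the name of the read-out), a lower number less inhibition), where compound 1 gives 40%. Compound 2 `O=C1OC(c2ccc(Cl)cc2)=C/C1=C\c1ccccc1[N+](=O)[O-]` shares the same core but carries a nitro group on its second aromatic ring, and in this assay compound 2 gives only 4%, a gap that lies beyond the usual scatter. Compound 3 `COc1ccc(/C=C2\C=C(c3ccc(Cl)cc3)OC2=O)cc1` has not yet been tested in this assay. It differs from compound 1 in one place: methoxy in place of chloro on an aromatic carbon. For the measured compounds named here, no measured pair shows what such a change does here, so the direction of the step is uncertain; a moderate loss, or no change beyond the scatter, seems equally plausible. Compound 3 is expected to give 33% in this assay, within a range of 12% to 55%, which means an estimated step of a number 7 percentage points lower from compound 1 to compound 3 (within the scatter).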

Compound 3, a percentage reported as inhibition, in the whole organism at one dose (the size of the read-out at that dose, not a potency): 4%
For compound 3 the middle estimate is 29 percentage points above the measured one; measured number below the stated range.
By their numbers in this assay, from the lowest: compounds 2 and 3 (each within the scatter of the next); then compound 1.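

In this assay, methoxy in place of chloro on an aromatic carbon, para to a large group, gives a number 36 percentage points lower from compound 1 to compound 3 (beyond the scatter). For the compounds shown here, this is the first one-place change measured on this core, and it shows that the group at this position matters: in this pair, chloro cannot be exchanged for methoxy without a large loss of inhibition at the dose given. Nothing available explains why the read-out falls.

This single step cannot tell whether the oxygen of the methoxy or the added carbon matters more, so a hydroxy or an ethyl group on the same carbon would help separate the two. From the compounds shown here alone, it also remains open whether a methyl or a fluoro group there would retain the inhibition that compound 1 shows, 40%.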